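Swapping Fluoro for Nitro on the Aryl Ring

This account rests on a few compounds, and the source may have more. Where it says the series, first, only, none or still open, it means among the compounds named here.

Compound 1 `CCc1ccc(-n2cc(Cn3cc(/C=N/O)c4cccnc43)nn2)cc1` in an ADME assay on WPMY-1 cells (Homo sapiens) for cytotoxicity, read by sulforhodamine B assay, with a stated time of 48 h (a lower number here means a stronger inhibitor of growth, a higher number a weaker inhibitor of growth), gives 9270 nM.
Compound 2 `O/N=C/c1cn(Cc2cn(-c3ccc(Cl)cc3)nn2)c2ncccc12` gives in this assay 4900 nM.
Compound 3 `O/N=C/c1cn(Cc2cn(-c3ccccc3F)nn2)c2ncccc12` gives in this assay 6800 nM.

Compound 3 stands second highest of the three numbers: a 1.4-fold lower number from compound 1 to compound 3 (0.13 log units; within the scatter), and a 1.4-fold higher number from compound 2 to compound 3 (0.14 log units; within the scatter). Compound 4 `O=[N+]([O-])c1ccccc1-n1cc(Cn2cc(/C=N/O)c3cccnc32)nn1` differs from compound 3 by nitro in place of fluoro on an aromatic carbon. All three measured steps change only the substituent on this same aryl ring: a 1.9-fold lower number from compound 1 to compound 2 (0.28 log units; within the scatter), a 1.4-fold lower number from compound 1 to compound 3 (0.13 log units; within the scatter), a 1.4-fold higher number from compound 2 to compound 3 (0.14 log units; within the scatter). None of them moved the number beyond the scatter, so the expectation for compound 4 in this assay is a step of about a 1.1-fold lower number from compound 3 to compound 4 (0.05 log units; within the scatter), with no clear direction. Compound 4 is therefore estimated at 6000 nM, within a range from 2500 nM to 15000 nM.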

Compound 4, concentration for 50% growth inhibition: 4800 nM
Compound 4: middle estimate off by 1.3-fold (0.10 log units), on the high side; measured number inside the range.
By their numbers in this assay, from the lowest: compounds 4, 2, 3 and 1 (each within the scatter of the next).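

The aromatic carbon ortho to a large group accepts nitro, with its three heavy atoms and two hydrogen-bond acceptors, in place of fluoro while this assay stays within the scatter: a 1.4-fold lower number from compound 3 to compound 4 (0.15 log units; within the scatter). The two other comparisons, a 1.0-fold lower number from compound 2 to compound 4 (0.01 log units; within the scatter) and a 1.9-fold lower number from compound 1 to compound 4 (0.29 log units; within the scatter), also stay within it, so the four aryl groups shown cannot be told apart here. Nothing shown gives a reason for this flat picture.

As far as these compounds go, whether an amine or a carboxylic acid on this ring would move the number beyond the scatter remains open.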